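Chloro on the fused ring: expected cytotoxicity of compound 3

The compounds below may be only part of what the source reports. "The series", "measured", "known", "first", "only" and "open" are said of these compounds alone.

Compound 1 `CC(=O)OC[C@H]1O[C@@H](CC(=O)/C=C2\C(=O)N(Cc3ccc(Br)cc3)c3ccccc32)[C@H](OC(C)=O)[C@@H](OC(C)=O)[C@@H]1OC(C)=O` is the reference point. In an ADME assay on Vero cells (Chlorocebus sabaeus) for cytotoxicity, read by resazurin assay, with a stated time of 72 h (on this read-out higher numbers stand for lower toxicity in this test and lower numbers for higher toxicity in this test), compound 1 gives 76500 nM, and it stands alongside compound 2 `CC(=O)OC[C@H]1O[C@@H](CC(=O)/C=C2\C(=O)Nc3ccccc32)[C@H](OC(C)=O)[C@@H](OC(C)=O)[C@@H]1OC(C)=O`, which gives 127000 nM, the two numbers lying within the usual scatter of each other: a 1.7-fold higher number from compound 1 to compound 2 (0.22 log units; within the scatter). Compound 3 `CC(=O)OC[C@H]1O[C@@H](CC(=O)/C=C2\C(=O)N(Cc3ccc(Br)cc3)c3ccc(Cl)cc32)[C@H](OC(C)=O)[C@@H](OC(C)=O)[C@@H]1OC(C)=O` differs from compound 1 by chloro in place of hydrogen on an aromatic carbon. Among the compounds with values here, no measured step touches this position, and the single step in hand, at the amide-type nitrogen, stayed within the scatter, so no movement beyond the scatter is expected in this assay in either direction. The estimate for compound 3 is 70000 nM with a range of 30000 nM to 160000 nM, meaning a 1.1-fold lower number from compound 1 to compound 3 (0.04 log units; within the scatter) is expected.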

Compound 3, half-maximal cytotoxic concentration: 93300 nM
Compound 3: the middle estimate sits 1.3-fold (0.12 log units) below what was measured; the measured number falls inside the stated range.
By their numbers in this assay, from the lowest: compounds 1, 3 and 2 (each within the scatter of the next).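

Chloro in place of hydrogen on an aromatic carbon of the six-membered aromatic ring of carbon only gives a 1.2-fold higher number from compound 1 to compound 3 (0.09 log units; within the scatter) in this assay. Within the data shown here, this position, which no earlier step touched, therefore takes this single chlorine atom without a step beyond the scatter, as the amide-type nitrogen did with its change. No evidence on hand bears on this result.

From the compounds shown here alone, whether an amine, a carboxylic acid or a longer chain on this same carbon would stay within the scatter remains open. So does whether chloro reads the same with the amide hydrogen in place of 4-bromobenzyl.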